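This account rests on a few compounds, and the source may have more. Where it says the series, first, only, none or still open, it means among the compounds named here.

Measured compounds in a functional assay on U-87MG ATCC cells for antiproliferative activity against U-87 MG (Homo sapiens), read by MTT assay, with a stated time of 48 h; on this read-out lower numbers stand for stronger inhibition and higher numbers for weaker inhibition:
compound 1 `COc1ccc(-c2nc(C)c(C(=O)CSc3nc(N)c(C#N)c(-c4ccc(Cl)cc4)n3)s2)cc1` gives 4540 nM
compound 2 `COc1ccc(-c2nc(C)c(C(=O)CSc3nc(-c4cccc(OC)c4)c(C#N)c(=O)[nH]3)s2)cc1` gives 15300 nM
compound 3 `COc1ccc(-c2nc(C)c(C(=O)CSc3nc(-c4ccc(OC)c(OC)c4)c(C#N)c(=O)[nH]3)s2)cc1` gives 12500 nM

Compound 1 shows the lowest of the three numbers; the gaps to compound 3 and compound 2 lie beyond the scatter. The difference between the core of compound 1 and the core of compound 3 is not broken down here. Within the pair that shares a core, the step of a 1.2-fold higher number from compound 3 to compound 2 (0.09 log units; within the scatter) goes with the change (hydrogen in place of methoxy on an aromatic carbon).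

Compound 4 `Cc1nc(-c2ccccc2)sc1C(=O)CSc1nc(N)c(C#N)c(-c2ccc(Cl)cc2)n1` is not yet measured. It differs from compound 1 by hydrogen in place of methoxy on an aromatic carbon, the same kind of change as in compound 3 to compound 2, though there the place was also ortho to a methoxy group; here it is only para to a large group. Because a 1.2-fold higher number from compound 3 to compound 2 (0.09 log units; within the scatter) stayed within the scatter, the step from compound 1 to compound 4 is expected to be small, a 1.2-fold higher number from compound 1 to compound 4 (0.08 log units; within the scatter). The expected value for compound 4 in this assay is 5500 nM, estimated between 2500 nM and 12000 nM.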

Compound 4, half-maximal inhibitory concentration: 10800 nM
The estimate for compound 4 lay 2.0-fold (0.29 log units) below the measured number; measured number inside the range.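

On the core of compound 1, hydrogen in place of methoxy gives a 2.4-fold higher number from compound 1 to compound 4 (0.38 log units; beyond the scatter) in this assay. Set beside the same change on the other core, the two steps do not differ beyond what repeated measurements allow: the same change on two cores in this assay, a 1.2-fold higher number (0.09 log units; within the scatter) from compound 3 to compound 2 and a 2.4-fold higher number (0.38 log units; beyond the scatter) from compound 1 to compound 4, 1.9-fold (0.29 log units) apart, within the scatter of two such steps. Within the data shown here, this shows no detectable dependence on the core across these two pairs, but it does not show that the steps are equal, since the change sits at a different place in each pair and only the step to compound 4 lies beyond the scatter.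

Still open, on these data alone, is what an ethoxy group or a chlorine atom in place of the methoxy would give on the core of compound 1. Also open, as far as these compounds go, is how 4-methoxyphenyl to phenyl would read on the core of compound 3.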